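The source may report more compounds than this note shows. Statements on the series, on what has been measured and on what is new or still open speak of the compounds shown alone.

Of the compounds shown here, three built on one shared core have been measured. Compound 1 `COc1ccccc1Nc1nc(SCc2ccc(C(F)(F)F)cc2)nc2ccccc12` carries a 2-methoxyphenyl group on the ring nitrogen, compound 2 `COc1ccc(Nc2nc(SCc3ccc(C(F)(F)F)cc3)nc3ccccc23)c(OC)c1` a 2,4-dimethoxyphenyl group, and compound 3 `COc1ccc(Nc2nc(SCc3ccc(C(F)(F)F)cc3)nc3ccccc23)cc1OC` a 3,4-dimethoxyphenyl group. In a functional assay on MCF7 cells (Homo sapiens) for cytotoxicity, read by MTT assay, with a stated time of 72 h (on this read-out higher numbers stand for weaker inhibition and lower numbers for stronger inhibition), compound 1 gives only a limit, > 50000 nM. Compound 2 likewise gives a limit in this assay, > 50000 nM. Compound 3 also gives a limit in this assay, > 50000 nM. As a result the steps a step that the two limits leave unreadable from compound 1 to compound 2, a step that the two limits leave unreadable from compound 1 to compound 3 and a step that the two limits leave unreadable from compound 2 to compound 3 cannot be sized, because of the limit of > 50000 nM in this assay, at which 3 of the 3 values shown sit.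

The cores of compound 1 and compound 3 differ by 3,4-dimethoxyphenyl in place of 2-methoxyphenyl on a nitrogen on an aromatic ring. The unmeasured compound 4 `COc1cc(Nc2nc(SCc3ccc(C(F)(F)F)cc3)nc3ccccc23)cc(OC)c1OC` differs from compound 3 by methoxy in place of hydrogen on an aromatic carbon. The same kind of change is seen from compound 1 to compound 2, (methoxy in place of hydrogen on an aromatic carbon); there the entering methoxy sits meta to a methoxy group and para to a large group, whereas in compound 4 it sits ortho to a methoxy group, meta to a large group and meta to a methoxy group, so the surroundings are not identical. That earlier step, a step that the two limits leave unreadable from compound 1 to compound 2, left no readable size.

Compound 4 is expected to show a step that the limit leaves unreadable from compound 3 to compound 4 in this assay, an expectation resting on compound 3 and its limit > 50000 nM together with the limit of > 50000 nM in this assay, at which 3 of the 3 values shown sit. Compound 4 is therefore estimated at 60000 nM, with an expected range from 20000 nM to 200000 nM, most likely again reported only as a limit.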

Compound 4, half-maximal inhibitory concentration: > 50000 nM
Compound 4: no number, only a limit; the forecaster's own chance of this, stated with the estimate: 80%; the middle value lies beyond the limit too.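

In this assay compound 4 gives only a limit, > 50000 nM. The methoxy step from compound 3 to compound 4 has no readable size, because both compounds give only a limit: the limit of > 50000 nM in this assay, at which 4 of the 4 values shown sit.

The compounds shown leave open what value any of them would reach in this assay, and so whether methoxy in place of hydrogen changes anything on the shared core.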